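The compounds below may be only part of what the source reports. "The series", "measured", "known", "first", "only" and "open" are said of these compounds alone.

Two compounds have been measured so far in a functional assay on ACHN cells (Homo sapiens) for inhibition, read by sulforhodamine B assay, with a stated time of 48 h, tested at 10 uM; on this read-out lower numbers stand for less inhibition and higher numbers for more inhibition at the one concentration tested (going by the name of the read-out):

Compound 1 `c1cn2cc(-c3ccsc3)nc(-c3ccc4ncn(C5CCCCC5)c4c3)c2n1`: 5.76%
Compound 2 `Brc1ccc(-c2cn3ccnc3c(-c3ccc4ncn(C5CCCCC5)c4c3)n2)cc1`: 21.4%

Compound 2 stands highest of these two numbers in this assay. For the measured compounds named here, its nearest neighbour is compound 1, and the one measured step between them, a number 15.6 percentage points higher from compound 1 to compound 2 (beyond the scatter), came with the exchange of thiophen-3-yl for 4-bromophenyl on an aromatic carbon.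

Compound 3 `COc1ccccc1-c1cn2ccnc2c(-c2ccc3ncn(C4CCCCC4)c3c2)n1` is the next compound to be measured. Compared with compound 2 the change is 2-methoxyphenyl in place of 4-bromophenyl on an aromatic carbon. Going by the values given here, no measured step involves a 2-methoxyphenyl, so the only step available bears on the present one merely through the shared position: it shows that swapping the group on that aromatic carbon moves the read-out by a modest amount, as seen from compound 1 to compound 2. Taking that as the likely scale, and allowing for either direction, compound 3 is expected to land somewhat below compound 2, with the expected step of a number 7.4 percentage points lower from compound 2 to compound 3 (within the scatter) sitting close to the scatter. The estimate for compound 3 in this assay is 14%, with a range from 3% to 28%.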

Compound 3, a percentage reported as inhibition, at one concentration (the size of the read-out at that concentration, not a potency): 4.48%
Compound 3: middle estimate off by 9.5 percentage points, on the high side, within the range that was stated.
By their numbers in this assay, from the lowest: compounds 3 and 1 (each within the scatter of the next); then compound 2.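

In this assay, the higher number of compound 2 does not carry over to a second phenyl group at this aromatic carbon: replacing 4-bromophenyl with 2-methoxyphenyl gave a number 16.9 percentage points lower from compound 2 to compound 3 (beyond the scatter), which undoes the gain seen earlier at the same place. Against thiophen-3-yl, the 2-methoxyphenyl group gave a number 1.3 percentage points lower from compound 1 to compound 3 (within the scatter), so a phenyl ring at this position is not enough on its own to separate a compound from the thiophene, and among these three compounds only the one with 4-bromophenyl stands apart. Nothing measured here accounts for this difference between the groups.

The compounds shown do not tell whether the higher number of compound 2 goes with the bromine or with the place of the substituent on the phenyl ring, as the two groups differ in both, and a 2-bromophenyl or a 4-methoxyphenyl would be needed to separate the two. Also open, going by these compounds, is how an unsubstituted phenyl or a group carrying an amine or a carboxylic acid would read at this carbon, and whether any change to the cyclohexyl group, which all three compounds share, would move the number.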